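Replacing iodo with thiophen-2-yl on a nucleoside core

This account rests on a few compounds, and the source may have more. Where it says the series, first, only, none or still open, it means among the compounds named here.

Of the compounds shown here, two have been measured in a functional assay on HCT-116 cells (Homo sapiens), read by MTT assay, with a stated time of 72 h; on this read-out higher numbers stand for weaker inhibition and lower numbers for stronger inhibition. Compound 1, with the structure `Nc1nc(N)c2c(-c3ccsc3)cn([C@@H]3O[C@H](CO)[C@@H](O)[C@H]3O)c2n1`, gives > 20000 nM in this assay, which is a limit of the assay rather than a number. Compound 2, with the structure `COc1ncnc2c1c(I)cn2[C@@H]1O[C@H](CO)[C@@H](O)[C@H]1O`, gives > 20000 nM in this assay, again only a limit. Within the data shown here, compound 2 therefore stands where everything measured so far stands: at the limit of > 20000 nM in this assay, at which 2 of the 2 values shown sit, so no ranking between compound 1 and compound 2 can be read from these values, and no step between measured compounds is available.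

Compound 3, with the structure `COc1ncnc2c1c(-c1cccs1)cn2[C@@H]1O[C@H](CO)[C@@H](O)[C@H]1O`, differs from compound 2 by one change: thiophen-2-yl in place of iodo on an aromatic carbon.

Among the measured compounds shown here, with no measured step to lean on, the only basis for an expectation is that compound 2 sits at the limit. A change of this kind could move the result in either direction, and a step beyond the scatter is possible, but there is no evidence pointing toward strong inhibition. Compound 3 is therefore expected to remain weak, with an estimated step of an at least 1.3-fold lower number from compound 2 to compound 3 (0.12 log units; that floor lies within the scatter), and an estimated value of 15000 nM with a range from 4000 nM to 40000 nM.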

Compound 3, half-maximal inhibitory concentration: 80 nM
The estimate for compound 3 lay 190-fold (2.27 log units) above the measured number; measured number outside the range, below it.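

Until now there was no number to work from, since every value shown was a limit. In this assay, putting thiophen-2-yl in place of iodo on this aromatic carbon gives an at least 250-fold lower number from compound 2 to compound 3 (2.39 log units; beyond the scatter), so the group on this carbon of the shared core can decide whether the compound registers as an inhibitor in these cells at all. That step is only a floor, and the real difference could be larger, because the value of compound 2 is a limit and not a number: the limit of > 20000 nM in this assay, at which 2 of the 3 values shown sit.

The result does not say what in the new group matters, whether the sulfur, the aromatic ring or simply a larger group on this carbon; a phenyl ring, a furan-2-yl ring or an amine in the same place would begin to separate these possibilities. On these data alone, compound 1 differs from compound 3 in more than one place, so the two cannot be compared directly, and the part played by the methoxy group on the core remains open.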